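The compounds below may be only part of what the source reports. "The series", "measured", "known", "first", "only" and "open" are said of these compounds alone.

Measured so far: compound 1 `COc1cc2c(Oc3ccc(NC(=O)c4nn(-c5ccccc5Br)c(=O)c5ccccc45)cc3F)ccnc2cc1OCCCN1CCCC1` gives 850 nM in a functional assay on HT-29 cells (Homo sapiens) for cytotoxicity, read by MTT assay, with a stated time of 72 h; a higher number here means a weaker inhibitor, a lower number a stronger inhibitor; compound 2 `COc1cc2c(Oc3ccc(NC(=O)c4nn(-c5ccc(F)cc5)c(=O)c5ccccc45)cc3F)ccnc2cc1OCCCN1CCC(C)CC1` gives 330 nM; compound 3 `COc1cc2c(Oc3ccc(NC(=O)c4nn(-c5cccc(F)c5)c(=O)c5ccccc45)cc3F)ccnc2cc1OCCCN1CCC(C)CC1` gives 500 nM.

Compound 3 stands second highest of the three numbers, with compound 2 nearest and compound 1 furthest, both within the scatter. For the measured compounds named here, the only single-place step is a 1.5-fold higher number from compound 2 to compound 3 (0.18 log units; within the scatter). Compound 4 `COc1cc2c(Oc3ccc(NC(=O)c4nn(-c5ccccc5Br)c(=O)c5ccccc45)cc3F)ccnc2cc1OCCCN1CCC(C)CC1` differs from compound 3 by 2-bromophenyl in place of 3-fluorophenyl on an aromatic nitrogen. Going by the values given here, no measured step covers this exchange; compound 1, which also carries the 2-bromophenyl, sits at 850 nM, within the scatter of compound 3. Taken together, compound 4 is expected to lie close to compound 3, with a step of a 1.3-fold higher number from compound 3 to compound 4 (0.11 log units; within the scatter) that need not exceed the scatter. Compound 4 is therefore estimated at 650 nM, in the range 300 nM to 1400 nM.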

Compound 4, half-maximal inhibitory concentration: 950 nM
Compound 4: middle estimate off by 1.5-fold (0.16 log units), on the low side; measured number inside the range.
By their numbers in this assay, from the lowest: compounds 2, 3, 1 and 4 (each within the scatter of the next, the first and the last beyond it).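

For the compounds shown here, on the aromatic nitrogen, 2-bromophenyl in place of 4-fluorophenyl gives the first step at this position to pass the scatter, a 2.9-fold higher number from compound 2 to compound 4 (0.46 log units; beyond the scatter), though it remains modest, while in place of 3-fluorophenyl it gives a 1.9-fold higher number from compound 3 to compound 4 (0.28 log units; within the scatter). With 2-bromophenyl kept, 4-methylpiperidin-1-yl in place of pyrrolidin-1-yl on the chain gives a 1.1-fold higher number from compound 1 to compound 4 (0.05 log units; within the scatter), so this exchange shows no change here. No measurement at hand accounts for these steps. The compounds shown do not separate the halogen from its place on the phenyl ring. As far as these compounds go, a 2-fluorophenyl or 4-bromophenyl on this nitrogen would bear on that, and how a morpholine on the chain would compare also stays open.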